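Moving fluoro: 2-fluorophenyl to 3-fluorophenyl

The source may hold more compounds than are shown below. What is called first, only, known or untested is meant among the compounds shown, and "the series" means these compounds.

Among the measured compounds shown here, in a toxicity assay on MT4 cells (Homo sapiens) for cytotoxicity, read by MTT assay (on this read-out lower numbers stand for higher toxicity in this test and higher numbers for lower toxicity in this test), compound 2 `Cc1cc(-c2ccccc2F)ccc1Oc1cc(N)nc(Nc2ccc(C#N)cc2)n1` gives 29500 nM and lies within the scatter of compound 1 `Cc1cc(-c2ccccc2)ccc1Oc1cc(N)nc(Nc2ccc(C#N)cc2)n1` with 20000 nM as the only other number. Compound 3 `Cc1cc(-c2cccc(F)c2)ccc1Oc1cc(N)nc(Nc2ccc(C#N)cc2)n1` differs from compound 2 by 3-fluorophenyl in place of 2-fluorophenyl on an aromatic carbon as 3-fluorophenyl in place of 2-fluorophenyl on an aromatic carbon. For the measured compounds named here, one measured step bears on this: a 1.5-fold higher number from compound 1 to compound 2 (0.17 log units; within the scatter) for fluoro in place of hydrogen on an aromatic carbon. The expected step of a 1.2-fold lower number from compound 2 to compound 3 (0.07 log units; within the scatter) stays within the scatter in this assay with no favoured direction. For compound 3 the estimated value is 25000 nM (range 12000 nM to 50000 nM).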

Compound 3, half-maximal cytotoxic concentration: 11300 nM
Beside the measured number, compound 3's estimate is 2.2-fold (0.34 log units) above it; the measured number lies below the stated range.
By their numbers in this assay, from the lowest: compounds 3, 1 and 2 (each within the scatter of the next, the first and the last beyond it).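

In this assay, the place of the fluoro on the phenyl ring now separates two compounds, with a 2.6-fold lower number from compound 2 to compound 3 (0.42 log units; beyond the scatter), whereas adding fluoro in compound 2 gave a step within the scatter. Compound 3 also stays within the scatter of the unsubstituted phenyl, with a 1.8-fold lower number from compound 1 to compound 3 (0.25 log units; within the scatter), so only the two fluorophenyl isomers are told apart. Nothing available explains the difference between them. From the compounds shown here alone, whether a chloro, methoxy or amine group on this phenyl ring would follow the same dependence on position remains open.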